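From a Furan to a Cyanophenyl on the Shared Core

This account rests on a few compounds, and the source may have more. Where it says the series, first, only, none or still open, it means among the compounds named here.

Compound 1 `Cc1ccc(-c2nc(N)c3ccsc3n2)o1` gives 493 nM in a functional assay on CHO-K1 cells for antagonist activity at adenosine receptor A1 (Homo sapiens), read by a beta-galactosidase reporter and cAMP accumulation, with stated times of 15 min and 6 h; a higher number here means a weaker inhibitor, a lower number a stronger inhibitor.
Compound 2 `Cc1ccc(-c2nc(N)c3cc(-c4ccccc4)sc3n2)o1` gives 520 nM in this assay.
Compound 3 `CCc1ccc(-c2nc(N)c3cc(Cc4ccccc4)sc3n2)o1` gives 223 nM in this assay.

Compound 3 has the lowest number of the three; compound 1 is its nearest neighbour and compound 2 the furthest, both gaps beyond the scatter. Compound 4 `N#Cc1cccc(-c2nc(N)c3cc(Cc4ccccc4)sc3n2)c1` differs from compound 3 in one place: 3-cyanophenyl in place of 5-ethylfuran-2-yl on an aromatic carbon. Among the compounds with values here, the only measured step, a 1.1-fold higher number from compound 1 to compound 2 (0.02 log units; within the scatter), changes a different position on the shared core and says nothing about swapping the group on this aromatic carbon. Compounds 2 and 3 differ in two places at once, and their values offer no separable guidance either. Within the data shown here, with no step bearing on the change, the expectation rests on compound 3 alone, with a wide range. Compound 4 is expected at about 400 nM, between 100 nM and 2000 nM. That amounts to an expected step of a 1.8-fold higher number from compound 3 to compound 4 (0.25 log units; within the scatter) in this assay.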

Compound 4, inhibition constant: 222 nM
The estimate for compound 4 lay 1.8-fold (0.26 log units) above the measured number; low and high end bracket the measured number.
By their numbers in this assay, from the lowest: compounds 4 and 3 (each within the scatter of the next); then compounds 1 and 2 (each within the scatter of the next).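

On this aromatic carbon between two ring nitrogen atoms, 3-cyanophenyl in place of 5-ethylfuran-2-yl gives a 1.0-fold lower number from compound 3 to compound 4 (0.00 log units; within the scatter) in this assay. The earlier compounds shown here all carried a furan here, whereas compound 4 shows that a six-membered aromatic ring of carbon only, bearing a nitrile, can give a value within the scatter of compound 3. No available evidence explains this match between the two groups.

Open, from the compounds shown here alone, is what a plain phenyl, an amine or a longer alkyl chain on this carbon would give. Going by these compounds, whether the nitrile itself contributes anything also remains open.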